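Working notes on a chloro-to-fluoro swap

A few compounds are considered here, and "the series" means these few. Any claim that something is new, unique, unknown or untested is made for them only; others in the source may bear on it.

Measured so far:
compound 1, `O=[N+]([O-])c1cccc(NS(=O)(=O)c2ccc(F)cc2)c1`, gives 7.85 in an ADME assay
compound 2, `O=[N+]([O-])c1cccc(NS(=O)(=O)c2ccc(Cl)cc2)c1`, gives 7.51
compound 3, `O=[N+]([O-])c1ccc(S(=O)(=O)Nc2ccc(Cl)cc2)cc1`, gives 6.24

Compound 2 and compound 1 share one core and differ in a single place: fluoro in place of chloro on an aromatic carbon. That change gave a number 0.34 log units higher from compound 2 to compound 1 (beyond the scatter). Compound 3 has the same atoms as compound 2 joined differently; the difference between the two cores is not broken down here. Compound 3 stands lowest of the three in this assay, beyond the scatter from both others.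

Compound 4, `O=[N+]([O-])c1ccc(S(=O)(=O)Nc2ccc(F)cc2)cc1`, is not yet measured. It differs from compound 3 by fluoro in place of chloro on an aromatic carbon, the same change as between compound 2 and compound 1. The step is expected to be a number 0.34 log units higher from compound 3 to compound 4 (beyond the scatter), because a number 0.34 log units higher from compound 2 to compound 1 (beyond the scatter) was seen on the other core. Compound 4 is therefore expected to give 6.58, within 6.25 to 6.95.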

Compound 4, acid dissociation constant: 6.45
Compound 4: middle estimate off by 0.13 log units, on the high side; low and high end bracket the measured number.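

In this assay, fluoro in place of chloro on the core of compound 3 gives a number 0.21 log units higher from compound 3 to compound 4 (within the scatter). Set beside the earlier step, the change does not differ measurably between the two cores: the same change on two cores in this assay, a number 0.34 log units higher (beyond the scatter) from compound 2 to compound 1 and a number 0.21 log units higher (within the scatter) from compound 3 to compound 4, 0.13 log units apart, within the scatter of two such steps. This supports carrying the swap between these two cores, but the new step on its own cannot be told from no change, and two cores do not establish a rule for the whole series.

The compounds shown carry only fluoro or chloro at this place, so it remains open how a bromo, methyl or methoxy group there would compare. Also open, going by these compounds, is whether the step would hold on cores bearing a nitrile or an amine instead of the nitro group.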